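Swapping an Ether Side Chain for an Amide

This account rests on a few compounds, and the source may have more. Where it says the series, first, only, none or still open, it means among the compounds named here.

In a functional assay on SMMC-7721 cells (Homo sapiens) for antiproliferative activity, read by MTT assay, with a stated time of 48 h (a higher number here means a weaker inhibitor, a lower number a stronger inhibitor), compound 1 (`COC/C1=C/C[C@](C)(CCC=C(C)C)/C=C/[C@@H](OC(=O)C=C(C)C)[C@](C)(O)/C=C/C1=O`) gives 11000 nM while compound 2 (`CC(C)=CCC[C@]1(C)/C=C/[C@@H](OC(=O)C=C(C)C)[C@](C)(O)/C=C/C(=O)/C(CN(C(C)C)C(C)C)=C\C1`) gives 340 nM and compound 3 (`COCOC/C1=C/C[C@](C)(CCC=C(C)C)/C=C/[C@@H](OC(=O)C=C(C)C)[C@](C)(O)/C=C/C1=O`) gives 3250 nM as the middle of the three numbers. Compound 4 (`CCN(CC)C(=O)/C1=C/C[C@](C)(CCC=C(C)C)/C=C/[C@@H](OC(=O)C=C(C)C)[C@](C)(O)/C=C/C1=O`) carries diethylcarbamoyl in place of (methoxymethoxy)methyl on a double-bonded ring carbon. Two modest steps frame compound 3: a 3.4-fold lower number from compound 1 to compound 3 (0.53 log units; beyond the scatter) on one side and a 9.6-fold higher number from compound 2 to compound 3 (0.98 log units; beyond the scatter) on the other. The large step of a 32-fold lower number from compound 1 to compound 2 (1.51 log units; beyond the scatter) came with diisopropylamino, which compound 4 does not carry. Within the data shown here, no measured compound carries diethylcarbamoyl, so no step beyond the scatter is expected in this assay and the direction stays open. The estimated step of a 1.1-fold lower number from compound 3 to compound 4 (0.03 log units; within the scatter) is only a central guess. Compound 4 is expected near 3000 nM with an estimated range from 700 nM to 12000 nM in this measurement.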

Compound 4, half-maximal inhibitory concentration: 13800 nM
Beside the measured number, compound 4's estimate is 4.6-fold (0.66 log units) below it, outside the stated range (above it).
By their numbers in this assay, from the lowest: compound 2; then compound 3; then compounds 1 and 4 (each within the scatter of the next).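

In this assay, diethylcarbamoyl on this double-bonded ring carbon gives a 4.2-fold higher number from compound 3 to compound 4 (0.63 log units; beyond the scatter) and a 41-fold higher number from compound 2 to compound 4 (1.61 log units; beyond the scatter), while a 1.3-fold higher number from compound 1 to compound 4 (0.10 log units; within the scatter) leaves it level with the methoxymethyl chain. A nitrogen in this side chain therefore does not by itself go with a low number: compound 2 has a low number with (diisopropylamino)methyl, but compound 4 does not with diethylcarbamoyl. Nothing available explains these differences. Still open, on these data alone, is whether a smaller amine such as dimethylaminomethyl, a ring amine such as piperidin-1-ylmethyl, or a carboxylic acid on this carbon would track compound 2 or compound 4.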